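Series notes: 2-fluorophenyl in place of 3-hydroxyphenyl

The compounds below may be only part of what the source reports. "The series", "measured", "known", "first", "only" and "open" are said of these compounds alone.

In a functional assay on NCI-H1299 cells (Homo sapiens) for inhibition, read by CCK-8 assay, with a stated time of 72 h, tested at 1 uM (on this read-out lower numbers stand for less inhibition of growth and higher numbers for more inhibition of growth at the one concentration tested), two compounds on the shared core have been measured so far. Compound 1 `CN(C)C(=O)c1cc2cnc(Nc3ccc(NC(=O)C4(C(=O)Nc5ccc(Cl)cc5)CC4)cc3)nc2n1C1CCCC1` gives 52.2%, and compound 2 `CN(C)C(=O)c1cc2cnc(Nc3ccc(NC(=O)C4(C(=O)Nc5cccc(O)c5)CC4)cc3)nc2n1C1CCCC1` gives 77.5%, the higher of the two numbers and clear of the scatter.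

Next in the series is compound 3 `CN(C)C(=O)c1cc2cnc(Nc3ccc(NC(=O)C4(C(=O)Nc5ccccc5F)CC4)cc3)nc2n1C1CCCC1`, with 2-fluorophenyl in place of 3-hydroxyphenyl on an amide-type nitrogen.

Among the compounds with values here, only one measured step bears on this change, at the same place: 3-hydroxyphenyl in place of 4-chlorophenyl gave a number 25.3 percentage points higher from compound 1 to compound 2 (beyond the scatter). Compound 3 gives up the 3-hydroxyphenyl of compound 2 and, like compound 1, carries a halogen-substituted phenyl. Within the data shown here, no measured compound carries 2-fluorophenyl, however, and a single step gives only a loose guide. Among the measured compounds shown here, a fall in this assay is therefore expected, probably smaller than the one step seen so far, with a wide margin. The estimated change is a number 15.5 percentage points lower from compound 2 to compound 3 (beyond the scatter). For compound 3 the expected value is 62%, with an estimated range of 42% to 82%.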

Compound 3, percent growth inhibition at one concentration: 70.2%
Estimate against measurement, compound 3: 8.2 percentage points below, and the stated range covers the measured number.
By their numbers in this assay, from the lowest: compound 1; then compounds 3 and 2 (each within the scatter of the next).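

In this assay, 2-fluorophenyl in place of 3-hydroxyphenyl on the amide-type nitrogen gives a number 7.3 percentage points lower from compound 2 to compound 3 (within the scatter), so compound 2 and compound 3 cannot be told apart here, although the hydrogen-bond donor and acceptor of the 3-hydroxyphenyl are absent from the entering group. Within the data shown here, the 3-hydroxyphenyl is therefore not the only group at this position that keeps the number clear of compound 1, and a halogen on the phenyl does not by itself mark the lower level: 2-fluorophenyl in place of 4-chlorophenyl gives a number 18 percentage points higher from compound 1 to compound 3 (beyond the scatter). The measurements show how far the number moves with each group but not the reason for these differences, and no supporting data bear on that question.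

Compound 1 and compound 3 differ in both the halogen and its ring position, so the compounds shown do not separate these two features. On these data alone, it remains open how a plain phenyl, a 2-chlorophenyl, a 4-fluorophenyl or a 3-aminophenyl on the same nitrogen would read at this single tested concentration, and whether compound 2 and compound 3 would stay together across a wider range of concentrations.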